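The compounds below may be only part of what the source reports. "The series", "measured", "known", "first", "only" and "open" are said of these compounds alone.

Of the compounds shown here, two have so far been measured in an assay on isolated protein for inhibition of hexokinase-3 (Rattus norvegicus), with a stated time of 6 h, tested at 10 mM; on this read-out higher numbers stand for more inhibition at the one concentration tested (going by the name of the read-out) and lower numbers for less inhibition. Compound 1, `O=C(CI)NCCCCCCCCNc1ncnc2c1ncn2[C@@H]1O[C@H](COP(=O)(O)OP(=O)(O)OP(=O)(O)O)[C@@H](O)[C@H]1O`, carries a plain chain between the core and its iodine-bearing end group; in this assay compound 1 gives 47%. Compound 2, `CN(CCCCN(C)c1ncnc2c1ncn2[C@@H]1O[C@H](COP(=O)(O)OP(=O)(O)OP(=O)(O)O)[C@@H](O)[C@H]1O)C(=O)CCCCCNC(=O)CI`, has a longer and differently built linker with extra methyl groups on its nitrogens; in this assay compound 2 gives 0%. On these two numbers compound 1 stands highest, and the gap to compound 2 lies beyond the usual scatter of the measurement.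

The next compound, compound 3, `O=C(I)NCC(=O)NCCCCCCNc1ncnc2c1ncn2[C@@H]1O[C@H](COP(=O)(O)OP(=O)(O)OP(=O)(O)O)[C@@H](O)[C@H]1O`, is derived from compound 1 by one change: a group of 8 heavy atoms (3 carbon, 2 nitrogen, 2 oxygen, 1 iodine; no ring) in place of a group of 7 heavy atoms (4 carbon, 1 nitrogen, 1 oxygen, 1 iodine; no ring), on a saturated chain carbon, six bonds along the chain from a nitrogen on an aromatic ring. The shared core and the nitrogen attached to it are untouched; the chain is reshaped near its far end, where one chain carbon gives way to a second amide.

Because compound 1 gives 47% and the change keeps most of its structure, the step of a number 12 percentage points lower from compound 1 to compound 3 (beyond the scatter) is expected to be a moderate drop, though possibly within the scatter. In this assay compound 3 is therefore estimated at 35%, within a range from 10% to 60%.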

Compound 3, a percentage reported as inhibition, at one concentration (the size of the read-out at that concentration, not a potency): 0%
For compound 3 the middle estimate is 35 percentage points above the measured one, outside the stated range (below it).
By their numbers in this assay, from the lowest: compounds 2 and 3 (each within the scatter of the next); then compound 1.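

In this assay the change on a saturated chain carbon, six bonds along the chain from a nitrogen on an aromatic ring, gives a number 47 percentage points lower from compound 1 to compound 3 (beyond the scatter) even though the shared core and the nitrogen attached to it stay the same. So the result shows that inhibition depends strongly on the far end of the chain: the 2-(((iodomethyl)carbonyl)amino)ethyl group with its 7 heavy atoms leaves, a group of 8 heavy atoms with 2 hydrogen-bond donors in place of 1 enters, and compound 3 gives 0% in this read-out. Nothing measured here bears on why a swap of similar size has so large an effect.

This single step alters several features at once, so it cannot separate the effect of the second amide from that of the reshaped chain end. Going by these compounds, it also remains open how a longer plain carbon chain, an ether oxygen within the chain, or an amine at this place would compare with the 2-(((iodomethyl)carbonyl)amino)ethyl group of compound 1.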